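From a bromophenyl limit to a dichlorophenyl estimate

The source may hold more compounds than are shown below. What is called first, only, known or untested is meant among the compounds shown, and "the series" means these compounds.

Measured in a functional assay on MCF7 cells (Homo sapiens) for cytotoxicity, read by MTT assay, with a stated time of 72 h; a higher number here means a weaker inhibitor, a lower number a stronger inhibitor:
- compound 1 `CNC(=O)c1cc(Oc2ccc(C(=O)/C=C/c3ccc(Cl)c(Cl)c3)cc2)ccn1` gives 13200 nM
- compound 2 `CNC(=O)c1cc(Oc2ccc(C(=O)/C=C/c3ccc(Br)cc3)cc2)ccn1` gives > 50000 nM (a limit)
- compound 3 `CNC(=O)c1cc(Oc2ccc(C(=O)/C=C/c3ccccc3)cc2)ccn1` gives 5960 nM

Compound 2 has no number, only a limit of the assay, so it stands at the limit of > 50000 nM in this assay, at which 1 of the 3 values shown sits. Compound 4 `CNC(=O)c1cc(Oc2ccc(C(=O)/C=C/c3ccc(Cl)cc3Cl)cc2)ccn1` has 2,4-dichlorophenyl in place of 4-bromophenyl, on a double-bonded chain carbon bound to a double-bonded chain carbon (2,4-dichlorophenyl in place of 4-bromophenyl on a double-bonded chain carbon bound to a double-bonded chain carbon). Among the measured compounds shown here, two measured steps bear on this change, an at least 3.7-fold higher number from compound 1 to compound 2 (0.57 log units; beyond the scatter) and an at least 8.3-fold lower number from compound 2 to compound 3 (0.92 log units; beyond the scatter), both beyond the scatter. Compound 1, which also carries a dichlorophenyl, gives 13200 nM, so a step of similar size towards a lower number is expected in this assay. The expected step runs an at least 3.5-fold lower number from compound 2 to compound 4 (0.55 log units; beyond the scatter). Compound 4 is estimated at 14000 nM, with an expected range from 4000 nM to 45000 nM.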

Compound 4, half-maximal inhibitory concentration: 3990 nM
Compound 4: middle estimate off by 3.5-fold (0.55 log units), on the high side, and the stated range ends above it.
By their numbers in this assay, from the lowest: compounds 4 and 3 (each within the scatter of the next); then compound 1. At a limit, above all of these: compound 2.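

With 2,4-dichlorophenyl in place of 4-bromophenyl, this assay gives an at least 12-fold lower number from compound 2 to compound 4 (1.09 log units; beyond the scatter), a step read against a limit of the assay: the limit of > 50000 nM in this assay, at which 1 of the 4 values shown sits.

The two dichlorophenyl groups do not give the same result, with a 3.3-fold lower number from compound 1 to compound 4 (0.52 log units; beyond the scatter), so the same two chlorines on this ring can give different numbers. Against phenyl, the step is a 1.5-fold lower number from compound 3 to compound 4 (0.17 log units; within the scatter), so halogens here do not always give a higher number, as they did in compound 1 and compound 2.

The compounds shown leave open whether 4-chlorophenyl would stand with compound 2 or with compound 4. They also leave open how a methoxy or dimethylamino group on this ring would read.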